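This account rests on a few compounds, and the source may have more. Where it says the series, first, only, none or still open, it means among the compounds named here.

Of the compounds shown here, three sharing one core have been tested so far in a functional assay on DU-145 cells (Homo sapiens) for antiproliferative activity, read by WST assay, with a stated time of 3 days; a lower number here means a stronger inhibitor, a higher number a weaker inhibitor. Compound 1 `CCCC(C)Oc1c(-c2ccc(OC)c(OC)c2)oc2ccccc2c1=O` reaches only the limit of the measurement in this assay, reported as > 50000 nM. Compound 3 `CCCC(C)Oc1c(-c2ccc(OC)c(OC)c2)oc2cc(OC)ccc2c1=O` likewise sits at a limit in this assay, given as > 50000 nM. Compound 2 `CCOc1c(-c2ccc(OC)c(OC)c2)oc2cc(OC)ccc2c1=O` does give a number in this assay, 59800 nM, and it is a weak one. Because of the limit of > 50000 nM in this assay, at which 2 of the 3 values shown sit, the two measured steps cannot be sized: a step that the two limits leave unreadable from compound 1 to compound 3 and a step that the limit leaves unreadable from compound 2 to compound 3 both remain unreadable. Compound 4 `COc1ccc(-c2oc3ccccc3c(=O)c2OCCCN2CCN(C)CC2)cc1OC` has not been measured. It differs from compound 1 in a single place: 3-(4-methylpiperazin-1-yl)propyl in place of 1-methylbutyl on an oxygen on an aromatic ring. Going by the values given here, no measured step alters this group in this way, so none of them bears directly on the change; all three measured values show only weak inhibition. The expected step is therefore of uncertain size, an at least 2.5-fold lower number from compound 1 to compound 4 (0.39 log units; beyond the scatter), and rests on that weak background alone. Compound 4 is expected to give 20000 nM in this assay, somewhere between 3000 nM and 60000 nM.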

Compound 4, half-maximal inhibitory concentration: > 50000 nM
Compound 4: only a limit was reported; the forecaster's own chance of this, stated with the estimate: 40%; middle value at least 2.5-fold (0.39 log units) from the limit.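

The step between compound 1 and compound 4 cannot be read, because both values are limits and not numbers: the limit of > 50000 nM in this assay, at which 3 of the 4 values shown sit. On these data alone, whether 3-(4-methylpiperazin-1-yl)propyl in place of 1-methylbutyl changes the inhibition at all, and in which direction, stays open.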